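Replacing Propyl with Trimethoxyphenyl: What to Expect

The source may hold more compounds than are shown below. What is called first, only, known or untested is meant among the compounds shown, and "the series" means these compounds.

Compound 2 `CCCc1nnc(SCC(=O)c2ccc(Cl)cc2)n1N1C(=O)c2ccccc2C1=O` was tested in a functional assay on A549 cells (Homo sapiens) for cytotoxicity, read by MTT assay, with a stated time of 48 h (a higher number here means a weaker inhibitor, a lower number a stronger inhibitor), where its reading is only a limit, > 200000 nM. Its two relatives sit in the same place. Compound 1 `C=CCSc1nnc(CCC)n1N1C(=O)c2ccccc2C1=O` gives the limit > 200000 nM. Compound 3 `CCCc1nnc(SCC(=O)c2ccccc2)n1N1C(=O)c2ccccc2C1=O` likewise gives the limit > 200000 nM. Because all three rest at the limit of > 200000 nM in this assay, at which 3 of the 3 values shown sit, the steps a step that the two limits leave unreadable from compound 1 to compound 2, a step that the two limits leave unreadable from compound 1 to compound 3 and a step that the two limits leave unreadable from compound 2 to compound 3 cannot be read as sizes. Compound 4 `COc1cc(-c2nnc(SCC(=O)c3ccc(Cl)cc3)n2N2C(=O)c3ccccc3C2=O)cc(OC)c1OC` differs from compound 2 by 3,4,5-trimethoxyphenyl in place of propyl on an aromatic carbon. Among the measured compounds shown here, no measured step touches this change, so the numbers say nothing about its direction. For compound 4 the estimate is 150000 nM, within 20000 nM to 400000 nM. The estimated step of an at least 1.3-fold lower number from compound 2 to compound 4 (0.12 log units; that floor lies within the scatter) is small, and a further limit rather than a number is expected as the likelier outcome.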

Compound 4, half-maximal inhibitory concentration: 9030 nM
Estimate against measurement, compound 4: 17-fold (1.22 log units) above, and the stated range ends above it.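

Changes to the group on sulfur gave steps that cannot be read, whereas this position gives a clear answer: 3,4,5-trimethoxyphenyl in place of propyl produces an at least 22-fold lower number from compound 2 to compound 4 (1.34 log units; beyond the scatter). Compound 4 is the only compound shown that gives a number rather than a limit: the limit of > 200000 nM in this assay, at which 3 of the 4 values shown sit.

Still open, as far as these compounds go, is whether the gain comes from the aromatic ring itself or from its three methoxy groups, which a plain phenyl group at this position would help separate. Also open, from the compounds shown here alone, is whether a longer chain or an amine here would give a readable value.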